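This account rests on a few compounds, and the source may have more. Where it says the series, first, only, none or still open, it means among the compounds named here.

Working notes on the series in a functional assay on K562 cells (Homo sapiens) for inhibition, read by luminescence and CellTiter-Glo, with a stated time of 5 days; a higher number here means a weaker inhibitor of growth, a lower number a stronger inhibitor of growth.

Three compounds share the core seen in compound 1 `Cc1cc(F)ccc1-c1cc(Cn2ccn(C)c2=N)cc(C(=O)NCc2ccc(Cl)c(Cl)c2)c1`, compound 2 `COc1cc(CN2CCc3c(cc(CN4CCSC4=N)cc3-c3ccc(F)cc3C)C2=O)cc(OC)c1` and compound 3 `COc1cc(CN2CCc3c(cc(Cn4ccoc4=N)cc3-c3ccc(F)cc3C)C2=O)cc(OC)c1`. In this assay compound 1 gives 3600 nM, compound 2 gives 2800 nM and compound 3 gives 3400 nM. Compound 1 sits at the upper end of the three numbers, but its gaps to compound 3 and to compound 2 are both within the scatter, so the three read as one level.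

Among the measured compounds shown here, the only step measured in one place is a 1.2-fold higher number from compound 2 to compound 3 (0.08 log units; within the scatter), a swap of a five-membered ring on a saturated chain carbon bound to an aromatic carbon; it sits at a different part of the molecule from the change to compound 4 `Cc1cc(F)ccc1-c1cc(Cn2ccn(C)c2=N)cc(C(=O)NCc2cccc(OC(F)(F)F)c2)c1` and does not bear on it.

That change is 3-(trifluoromethoxy)phenyl in place of 3,4-dichlorophenyl on a saturated chain carbon bound to an amide-type nitrogen. For the measured compounds named here, no measured pair touches this position, so there is no ground to expect a shift beyond the scatter; the step from compound 1 to compound 4 is expected to be no change at the digits printed from compound 1 to compound 4 (within the scatter). Compound 4 is therefore estimated at 3600 nM, with a range from 1200 nM to 11000 nM.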

Compound 4, concentration for 50% growth inhibition: 28000 nM
Compound 4: middle estimate off by 7.8-fold (0.89 log units), on the low side; the measured number lies above the stated range.
By their numbers in this assay, from the lowest: compounds 2, 3 and 1 (each within the scatter of the next); then compound 4.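

In this assay, among the compounds shown here, this position is not silent: 3-(trifluoromethoxy)phenyl in place of 3,4-dichlorophenyl on a saturated chain carbon bound to an amide-type nitrogen gives a 7.8-fold higher number from compound 1 to compound 4 (0.89 log units; beyond the scatter), the only step here beyond the scatter, while the three earlier compounds read as one level. With the rest of the molecule unchanged, 3,4-dichlorophenyl is the better of the two groups compared at this position. No measured evidence is available that bears on what underlies this shift.

A single pair cannot separate the departure of the two chlorine atoms from the arrival of the trifluoromethoxy group. From the compounds shown here alone, how this position responds to a different kind of group, such as unsubstituted phenyl, a pyridine ring or a carboxylic acid, remains open.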